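The source may hold more compounds than are shown below. What is called first, only, known or untested is meant among the compounds shown, and "the series" means these compounds.

Measured compounds in an in vitro assay on BTI-TN-5B1-4 cells for inhibition of Amine oxidase [flavin-containing] A (Homo sapiens), read by Amplex Red, with a stated time of 15 min, tested at 100 uM; on this read-out higher numbers stand for more inhibition at the one concentration tested (going by the name of the read-out) and lower numbers for less inhibition:
compound 1, `C/C(=N/Nc1nc(-c2ccc(C#N)cc2)cs1)c1ccco1`, gives 40%
compound 2, `C/C(=N/Nc1nc(-c2ccc(C#N)cc2)cs1)c1cccs1`, gives 40%
compound 3, `C/C(=N/Nc1nc(-c2ccc(C#N)cc2)cs1)c1cccnc1`, gives 40%

The three measured compounds share one core and differ only in the aromatic ring on a carbon with a double bond to nitrogen. Compound 2 stands level with compounds 1 and 3 at the digits printed. Its nearest neighbour is compound 1, with no change at the digits printed from compound 1 to compound 2 (within the scatter), and its furthest is compound 3, with no change at the digits printed from compound 2 to compound 3 (within the scatter); the remaining pair shows no change at the digits printed from compound 1 to compound 3 (within the scatter). Exchanging furan-2-yl, thiophen-2-yl and pyridin-3-yl thus leaves this assay untouched within the scatter.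

Compound 4, `C/C(=N/Nc1nc(-c2ccc(F)cc2)cs1)c1cccs1`, is the unmeasured partner of compound 2. The change is fluoro in place of cyano on an aromatic carbon. Going by the values given here, none of the measured steps touches this position: all three vary the other end of the molecule, so no measured step bears directly on the step from compound 2 to compound 4. Among the compounds with values here, what the data offer is only that the cyano-bearing core sits at the same level in every measured case. On that basis compound 4 is expected to stay near compound 2, with an estimated step of a number 5 percentage points lower from compound 2 to compound 4 (within the scatter). The estimate for compound 4 in this assay is 35%, with a range from 15% to 55%.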

Compound 4, a percentage reported as inhibition, at one concentration (the size of the read-out at that concentration, not a potency): 40%
The estimate for compound 4 lay 5 percentage points below the measured number; the measured number falls inside the stated range.
By their numbers in this assay, from the lowest: compounds 1, 2, 3 and 4 (each within the scatter of the next).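

Going by these compounds alone, this is the first step at the aromatic carbon para to a large group, and in this assay fluoro in place of cyano gives no change at the digits printed from compound 2 to compound 4 (within the scatter) on the compound carrying thiophen-2-yl. The earlier compounds shown here showed only that the other end of the molecule could be exchanged among furan-2-yl, thiophen-2-yl and pyridin-3-yl with cyano held fixed, whereas here cyano itself leaves, taking with it its triple bond and its hydrogen-bond acceptor, and the read-out stays within the scatter, so with thiophen-2-yl this level of inhibition at the one concentration tested does not depend on the nitrile. Nothing shown here gives a reason for this result.

The compounds shown leave open whether fluoro behaves in the same way when furan-2-yl or pyridin-3-yl stands at the other end of the molecule, since fluoro appears only with thiophen-2-yl. They also leave open whether a quite different group at this aromatic carbon, such as an amine, a carboxylic acid or a longer alkyl chain, would move the read-out beyond the scatter.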